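Replacing the hydroxyethyl piperidine of compound 3

The source may report more compounds than this note shows. Statements on the series, on what has been measured and on what is new or still open speak of the compounds shown alone.

In a functional assay on A549 cells (Homo sapiens) for antiproliferative activity, read by MTT assay, with a stated time of 72 h (a lower number here means a stronger inhibitor, a higher number a weaker inhibitor), compound 1 `COc1cc2c(Nc3ccc(C#N)cc3)ncnc2cc1OCCCN1CCC(C)CC1` gives 32300 nM. Compound 2 `COc1cc2c(Nc3ccc(C#N)cc3)ncnc2cc1OCCCN1CCC(CO)CC1` reaches only a limit, > 100000 nM. Compound 3 `COc1cc2c(Nc3ccc(C#N)cc3)ncnc2cc1OCCCN1CCCCC1CCO` is also recorded only as a limit, > 100000 nM, so it has no exact number. Both hydroxy-bearing compounds lie well off compound 1, with an at least 3.0-fold higher number from compound 1 to compound 2 (0.49 log units; beyond the scatter) and an at least 3.0-fold higher number from compound 1 to compound 3 (0.49 log units; beyond the scatter). Compound 4 `COc1cc2c(Nc3ccc(C#N)cc3)ncnc2cc1OCCCN1CCC(N2CCCCC2)CC1` changes the amine: 4-(piperidin-1-yl)piperidin-1-yl in place of 2-(2-hydroxyethyl)piperidin-1-yl on a saturated chain carbon, three bonds along the chain from an oxygen on an aromatic ring. Like compound 1, with its 32300 nM, compound 4 carries no hydroxy group, so it is expected to return towards that value, though the second ring adds uncertainty. In this assay a modest move to a lower number is expected, an at least 2.8-fold lower number from compound 3 to compound 4 (0.45 log units; beyond the scatter). For compound 4 the estimated value is 35000 nM, with an expected range of 10000 nM to 100000 nM.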

Compound 4, half-maximal inhibitory concentration: 30700 nM
Beside the measured number, compound 4's estimate is 1.1-fold (0.06 log units) above it; the measured number falls inside the stated range.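

In this assay, the larger 4-(piperidin-1-yl)piperidin-1-yl group leaves the result level with the 4-methylpiperidin-1-yl group of compound 1, with a 1.1-fold lower number from compound 1 to compound 4 (0.02 log units; within the scatter), so this place on the chain accepts a second ring. The same group stands clear of both hydroxy-bearing amines, with an at least 3.2-fold lower number from compound 3 to compound 4 (0.51 log units; beyond the scatter) and with an at least 3.2-fold lower number from compound 2 to compound 4 (0.51 log units; beyond the scatter). These two steps start from limits, not numbers: the limit of > 100000 nM in this assay, at which 2 of the 4 values shown sit.

On these data alone, whether any amine here can give a much lower number remains open. So does how a morpholine or a piperazine in the same place, or a longer chain before the amine, would read.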